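The source may hold more compounds than are shown below. What is called first, only, known or untested is meant among the compounds shown, and "the series" means these compounds.

Measured compounds:
compound 1, `Cc1cccc(NC(=S)N/N=C/c2ccc3ccccc3n2)c1`, > 100000 nM in a functional assay on HL-60 cells (Homo sapiens) for antiproliferative activity, read by sulforhodamine B assay, with a stated time of 72 h (a lower number here means a stronger inhibitor, a higher number a weaker inhibitor), a limit of the assay
compound 2, `S=C(NCc1ccccc1)N/N=C/c1ccc2ccccc2n1`, 21900 nM in this assay
compound 3, `S=C(N/N=C/c1ccc2ccccc2n1)Nc1cccc(Br)c1`, 53800 nM in this assay

Compound 3 gives the highest of the two numbers shown; its nearest neighbour is compound 2, with a 2.5-fold higher number from compound 2 to compound 3 (0.39 log units; beyond the scatter). For compound 1 only a limit is known, (the limit of > 100000 nM in this assay, at which 1 of the 3 values shown sits), so its place relative to compound 3 is not settled beyond an at least 1.8-fold lower number from compound 1 to compound 3 (0.26 log units; that floor lies within the scatter).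

Compound 4, `NC(=S)N/N=C/c1ccc2ccccc2n1`, has not yet been measured. It differs from compound 3 by hydrogen in place of 3-bromophenyl on an amide-type nitrogen. Among the measured compounds shown here, two measured steps bear on this position. The step of a 2.5-fold higher number from compound 2 to compound 3 (0.39 log units; beyond the scatter) shows the 3-bromophenyl group giving a higher number than benzyl, and an at least 4.5-fold lower number from compound 1 to compound 2 (0.65 log units; beyond the scatter) shows benzyl giving a lower number than 3-methylphenyl. Both steps exchange one substituent for another; none removes the substituent altogether, so the size of the present step is uncertain. Because a 2.5-fold higher number from compound 2 to compound 3 (0.39 log units; beyond the scatter) is modest, compound 4 is expected to stay near compound 3, with a slight lean toward a higher number; the step of a 1.2-fold higher number from compound 3 to compound 4 (0.08 log units; within the scatter) is estimated. Compound 4 is therefore expected at 65000 nM in this assay, within 15000 nM to 250000 nM.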

Compound 4, half-maximal inhibitory concentration: > 100000 nM
Compound 4 gave a limit, no number (the forecaster's own chance of this, stated with the estimate: 35%); middle value at least 1.5-fold (0.18 log units) away from the limit.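

In this assay compound 4 gives > 100000 nM, a limit of the assay and not a number. This is the first change shown that removes the substituent on the amide-type nitrogen instead of exchanging it, and the comparison with benzyl gives an at least 4.5-fold higher number from compound 2 to compound 4 (0.65 log units; beyond the scatter), so a benzyl group on this nitrogen goes with a measurable potency that the bare hydrogen does not reach. The comparison with 3-bromophenyl gives an at least 1.8-fold higher number from compound 3 to compound 4 (0.26 log units; that floor lies within the scatter), a floor that does not by itself separate the two compounds, and the step between the two compounds without a number cannot be read because compound 1 and compound 4 both sit at the limit: the limit of > 100000 nM in this assay, at which 2 of the 4 values shown sit.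

How much potency a group on this nitrogen can add remains open, since only benzyl, 3-bromophenyl and 3-methylphenyl are shown there and each result is a weak one or a limit. Also open, going by these compounds, is whether a small methyl group, a longer phenethyl chain or a benzyl ring carrying bromo would lower the number further than benzyl alone.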